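The source may hold more compounds than are shown below. What is called first, only, known or untested is meant among the compounds shown, and "the series" means these compounds.

Measured compounds:
Compound 1, `OC(CCn1nc2c(Br)c(Br)c(Br)c(Br)c2n1)c1ccccc1`: 84%
Compound 2, `CC(O)CCn1nc2c(Br)c(Br)c(Br)c(Br)c2n1`: 86%

In a functional assay on CCRF-CEM cells (Homo sapiens) for antiproliferative activity, read by MTT assay, with a stated time of 48 h, tested at 25 uM (a lower number here means a stronger effect, a higher number a weaker effect of the compound at the concentration tested), compound 1 gives 84% and compound 2 gives 86%. Compound 2 stands alongside compound 1, the two numbers within the scatter of each other; only these two compounds have been measured, so there is no wider spread against which to place compound 2. Compound 3, `OC(CCn1nc2c(Br)c(Br)c(Br)c(Br)c2n1)c1ccc(Cl)cc1`, has not yet been measured in this assay. Its difference from compound 2 is 4-chlorophenyl in place of methyl on a saturated chain carbon bound to an oxygen on a saturated carbon and a saturated chain carbon.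

Among the measured compounds shown here, the one measured step that bears on this change is a number 2 percentage points higher from compound 1 to compound 2 (within the scatter), which exchanged methyl for phenyl at the same place and left the number within the scatter. For the measured compounds named here, compound 3 returns a six-membered aromatic ring of carbon only to that place, now carrying a chlorine; no measured pair shows what the chlorine adds. On this basis a step within the scatter is expected from compound 2 to compound 3, a number 3 percentage points lower from compound 2 to compound 3 (within the scatter). Compound 3 is therefore estimated at 83% in this assay, within a range from 70% to 95%.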

Compound 3, a percentage reported as activity, at one concentration (the size of the read-out at that concentration, not a potency): 69%
Beside the measured number, compound 3's estimate is 14 percentage points above it; the measured number lies below the stated range.
By their numbers in this assay, from the lowest: compound 3; then compounds 1 and 2 (each within the scatter of the next).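

In this assay, phenyl and methyl on this saturated chain carbon could not be told apart, so the earlier pair gave no sign that this place could move the number at all; compound 3 now shows that it can, with 4-chlorophenyl giving a number 17 percentage points lower from compound 2 to compound 3 (beyond the scatter). The closer comparison isolates the chlorine, since chloro in place of hydrogen on an aromatic carbon gives a number 15 percentage points lower from compound 1 to compound 3 (beyond the scatter), and so the shift appears only when the ring carries this substituent, not with the ring alone. Nothing at hand explains why the chlorine has this effect.

The compounds shown leave open whether this shift is particular to chlorine or would also appear with a fluoro, a bromo, a methoxy or an amine in place of the chloro on 4-chlorophenyl. They also leave open how these differences would appear at other concentrations, as each number is the size of the read-out at a single concentration and not a potency.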